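The source may report more compounds than this note shows. Statements on the series, on what has been measured and on what is new or still open speak of the compounds shown alone.

Measured so far:

Compound 1, `CCCCCCN(C)/N=N/c1ccc(C(=O)O)cc1`: 1.95
Compound 2, `CCCCCCCN(C)/N=N/c1ccc(C(=O)O)cc1`: 2.58
Compound 3, `CN(C)/N=N/c1ccc(C(N)=O)cc1`: 1.2

All three numbers come from a physicochemical assay for lipophilicity; a higher number here means a more lipophilic compound, a lower number a more polar compound. Compound 1 and compound 2 differ in one place only, by methyl in place of hydrogen on a saturated chain carbon, six bonds along the chain from an amine nitrogen. That change gave a number 0.63 log units higher from compound 1 to compound 2 (beyond the scatter). Compound 3 stands apart from the other two: the difference between its core and the core of compound 1 is not broken down here. In this assay compound 3 gives the lowest of the three numbers, and its value lies beyond the scatter below both compound 1 and compound 2.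

Compound 4, `CCN(C)/N=N/c1ccc(C(N)=O)cc1`, has not yet been measured in this assay. It differs from compound 3 by methyl in place of hydrogen on a saturated chain carbon bound to an amine nitrogen. Within the data shown here, this is the same kind of change as the one from compound 1 to compound 2, though not the same: in compound 4 the new methyl sits on a saturated chain carbon bound to an amine nitrogen, whereas in compound 2 it sits six bonds along the chain from an amine nitrogen. Among the measured compounds shown here, since one extra chain carbon gave a number 0.63 log units higher from compound 1 to compound 2 (beyond the scatter) in the only matched pair available, a step of similar size is expected here, and the estimate is a number 0.55 log units higher from compound 3 to compound 4 (beyond the scatter). Because compound 3 gives 1.2, compound 4 is expected to give about 1.75, most likely between 1.4 and 2.1.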

Compound 4, partition coefficient: 1.7
For compound 4 the middle estimate is 0.05 log units above the measured one; the measured number falls inside the stated range.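

The same kind of change, methyl in place of hydrogen, can now be read on two cores in this assay: it gave a number 0.63 log units higher from compound 1 to compound 2 (beyond the scatter) and a number 0.50 log units higher from compound 3 to compound 4 (beyond the scatter), so the number went up in both matched pairs and neither step stayed inside the scatter. This shows only that the direction held in these two pairs, and it gives no rule for other cores: the new methyl sits on a saturated chain carbon bound to an amine nitrogen in compound 4 but six bonds along the chain from an amine nitrogen in compound 2, so two pairs cannot separate the part played by the core from the part played by the place. Nothing measured here accounts for the size of either step.

The compounds shown leave open whether a propyl chain on the core of compound 4 would raise the number again, or how far a chain ending in a hydroxyl group would shift it. They also leave open whether the same methyl change would give a step of this kind on a core carrying an amine where compound 3 has its amide.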